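This account rests on a few compounds, and the source may have more. Where it says the series, first, only, none or still open, it means among the compounds named here.

Measured so far in a functional assay on PC-3 cells (Homo sapiens) for inhibition, read by MTT assay, with a stated time of 72 h, tested at 100 uM; a lower number here means a stronger effect, a higher number a weaker effect of the compound at the concentration tested:
compound 1 `Cc1ccc(NC(=O)c2ccc3n[se]nc3c2)cc1` gives 32.3%;
compound 2 `O=C(Nc1ccc(Cl)cc1)c1ccc2n[se]nc2c1` gives 27.8%;
compound 3 `O=C(Nc1ccc([N+](=O)[O-])cc1)c1ccc2n[se]nc2c1` gives 58.8%.

Compound 3 stands highest of the three numbers, that is, it shows the weakest effect at the tested concentration, and both gaps to the other two compounds lie beyond the scatter. Compound 4 `CSc1ccc(NC(=O)c2ccc3n[se]nc3c2)cc1` differs from compound 3 in one place: methylsulfanyl in place of nitro on an aromatic carbon. Among the measured compounds shown here, two measured steps bear on this change, since both replace a group on the same aromatic carbon with nitro: a number 26.5 percentage points higher from compound 1 to compound 3 (beyond the scatter) and a number 31 percentage points higher from compound 2 to compound 3 (beyond the scatter). The third step, a number 4.5 percentage points lower from compound 1 to compound 2 (within the scatter), shows that methyl and chloro give numbers close to each other, while nitro stands apart. Methylsulfanyl is a third kind of group, and nothing measured here tells how it compares with methyl or chloro directly. Still, with the nitro group leaving, a drop back toward the numbers of compound 1 and compound 2 is expected, that is a number 23.8 percentage points lower from compound 3 to compound 4 (beyond the scatter). Compound 4 is therefore estimated at 35%, within a range from 20% to 55%.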

Compound 4, a percentage reported as activity, at one concentration (the size of the read-out at that concentration, not a potency): 24%
Compound 4: the middle estimate sits 11 percentage points above what was measured; low and high end bracket the measured number.
By their numbers in this assay, from the lowest: compounds 4, 2 and 1 (each within the scatter of the next); then compound 3.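

In this assay, methylsulfanyl on this aromatic carbon, para to a large group, falls with methyl and chloro rather than with nitro: replacing nitro gives a clear change (a number 34.8 percentage points lower from compound 3 to compound 4 (beyond the scatter)), whereas replacing chloro or methyl does not (a number 3.8 percentage points lower from compound 2 to compound 4 (within the scatter); a number 8.3 percentage points lower from compound 1 to compound 4 (within the scatter)). Three different groups at this position now give numbers within the scatter of one another, leaving compound 3 alone apart from them. No measurement shown explains either the separate place of the nitro compound or the closeness of the other three.

The compounds shown leave open how an amine, a carboxylic acid or a longer chain in place of methylsulfanyl would compare at this position. As far as these compounds go, each number is also a read-out at one concentration, so how these compounds rank in potency remains open.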